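Aryl substitution on the ring nitrogen: compounds 2 and 3

A few compounds are considered here, and "the series" means these few. Any claim that something is new, unique, unknown or untested is made for them only; others in the source may bear on it.

Measured so far in a functional assay on A549 cells (Homo sapiens) for antiproliferative activity, read by MTT assay, with a stated time of 72 h; a lower number here means a stronger inhibitor, a higher number a weaker inhibitor:
- compound 1 `CCCNC(=O)c1cc(Oc2ccc(NC(=O)c3cc4cccnc4n(-c4ccccc4)c3=O)cc2)ccn1` gives 95 nM
- compound 2 `CCCNC(=O)c1cc(Oc2ccc(NC(=O)c3cc4cccnc4n(-c4ccc(Br)cc4F)c3=O)cc2)ccn1` gives 1310 nM

Compound 2 holds the highest of the two numbers; its nearest neighbour is compound 1, reached by the step of a 14-fold higher number from compound 1 to compound 2 (1.14 log units; beyond the scatter). Compound 3 `CCCNC(=O)c1cc(Oc2ccc(NC(=O)c3cc4cccnc4n(-c4ccc(F)c(Cl)c4)c3=O)cc2)ccn1` differs from compound 2 by 3-chloro-4-fluorophenyl in place of 4-bromo-2-fluorophenyl on an aromatic nitrogen. Within the data shown here, the only measured step that touches the same position is a 14-fold higher number from compound 1 to compound 2 (1.14 log units; beyond the scatter), a large one, and it compares an unsubstituted phenyl with a halogenated one; no measured step compares two halogenated phenyls with each other, so the size of the present change has no direct precedent. Both compound 2 and compound 3 carry a halogenated phenyl, so the expectation is a number closer to compound 2 than to compound 1, with the move from compound 2 to compound 3 expected to be a 2.2-fold lower number from compound 2 to compound 3 (0.34 log units; beyond the scatter) in this assay, a modest shift downward that may well stay within the scatter. For compound 3 the estimate in this assay is 600 nM, with a range from 130 nM to 2800 nM.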

Compound 3, half-maximal inhibitory concentration: 590 nM
For compound 3 the middle estimate is 1.0-fold (0.01 log units) above the measured one; measured number inside the range.
By their numbers in this assay, from the lowest: compound 1; then compound 3; then compound 2.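

In this assay, halogenated phenyls on the aromatic nitrogen are not interchangeable: a 2.2-fold lower number from compound 2 to compound 3 (0.35 log units; beyond the scatter) is a modest step but lies beyond the scatter, so the outcome depends on which halogenated phenyl is present, not merely on halogen being there. Compound 3 still does not return to the level of the unsubstituted phenyl, with a 6.2-fold higher number from compound 1 to compound 3 (0.79 log units; beyond the scatter), although this step is smaller than a 14-fold higher number from compound 1 to compound 2 (1.14 log units; beyond the scatter), and among these three compounds the unsubstituted phenyl gives the lowest number. No available evidence accounts for either new step.

The change from 4-bromo-2-fluorophenyl to 3-chloro-4-fluorophenyl alters both the heavier halogen and the substitution pattern, so the compounds shown do not separate the two; 4-fluorophenyl and 3-chlorophenyl would be the informative single changes. Going by these compounds, it also remains open whether any substituted phenyl can match the unsubstituted one, for instance one bearing a methyl, a methoxy or an amine rather than a halogen.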